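A few compounds are considered here, and "the series" means these few. Any claim that something is new, unique, unknown or untested is made for them only; others in the source may bear on it.

Compound 1 `O=c1cc(N2CCN(CC3CCC(NS(=O)(=O)c4ccccc4)CC3)CC2)sc2c([N+](=O)[O-])cc(C(F)(F)F)cc12`: > 64 ug/mL (a limit)
Compound 2 `O=C(NC1CCC(CN2CCN(c3cc(=O)c4cc(C(F)(F)F)cc([N+](=O)[O-])c4s3)CC2)CC1)c1ccccc1`: 44.3 ug/mL
Compound 3 `O=C(OC1CCC(CN2CCN(c3cc(=O)c4cc(C(F)(F)F)cc([N+](=O)[O-])c4s3)CC2)CC1)c1ccco1`: not yet measured

Among the compounds with values here, in an ADME assay on Vero cells (Chlorocebus sabaeus) for cytotoxicity, read by MTT assay, with a stated time of 48 h (on this read-out higher numbers stand for weaker inhibition and lower numbers for stronger inhibition), compound 2 gives 44.3 ug/mL, the only true number so far. Compound 1 gives > 64 ug/mL, which is a limit of the assay.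

Compound 3 carries ((furan-2-yl)carbonyl)oxy in place of benzamido on a saturated ring carbon. Within the data shown here, the only measured step, an at least 1.4-fold lower number from compound 1 to compound 2 (0.15 log units; that floor lies within the scatter), starts from that limit (the limit of > 64 ug/mL in this assay, at which 1 of the 2 values shown sits), and its floor lies within the scatter. It is a different change, so it offers weak guidance. The expected step, a 1.0-fold higher number from compound 2 to compound 3 (0.01 log units; within the scatter), is therefore none beyond the scatter, in no particular direction. Compound 3 is estimated at 45 ug/mL, with an expected range of 20 ug/mL to 64 ug/mL.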

Compound 3, half-maximal inhibitory concentration: > 64 ug/mL
Compound 3: only a limit was reported (the forecaster's own chance of this, stated with the estimate: 25%); middle value at least 1.4-fold (0.15 log units) away from the limit.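

At this position on the saturated ring carbon, ((furan-2-yl)carbonyl)oxy in place of benzamido gives an at least 1.4-fold higher number from compound 2 to compound 3 (0.15 log units; that floor lies within the scatter) in this assay. Compound 3 gives > 64 ug/mL, which is a limit, so this position can carry a five-membered aromatic ring and 0 hydrogen-bond donors with no true number reached. The step between compound 1 and compound 3 cannot be read, because both values are limits: the limit of > 64 ug/mL in this assay, at which 2 of the 3 values shown sit.

Going by these compounds, how far compound 3 truly lies from compound 2 stays open. So does what an amine or a longer chain on this ring carbon would give.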